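The compounds below may be only part of what the source reports. "The series", "measured", "known", "first", "only" and "open" are said of these compounds alone.

Measured so far in a functional assay on PC-3 cells (Homo sapiens) for antiproliferative activity, read by sulforhodamine B assay, with a stated time of 3 days; a higher number here means that more compound is needed for the effect, a lower number that less compound is needed:
- compound 1 `CCCOC1=C(CCC)C(=O)/C(=C(O)/C=C/c2ccccc2)C(=O)C1(CCC)CCC`: 8.6 uM
- compound 2 `CCCC1=C(OCC(C)C)C(CCC)(CCC)C(=O)/C(=C(O)\C=C\c2ccccc2)C1=O`: 12.2 uM
- compound 3 `CCCC1=C(OC)C(CCC)(CCC)C(=O)/C(=C(O)\C=C\c2ccc(Br)cc2)C1=O`: 4.7 uM

Going by the values given here, compound 2 gives the highest number of the three in this assay, though its distance to compound 1 is within the scatter; the gap to compound 3, which carries a bromine on the phenyl and a methoxy in place of the isobutoxy, is beyond it, and no single-point step to compound 3 is available.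

Compound 4 `CCCCOC1=C(CCC)C(=O)/C(=C(O)/C=C/c2ccccc2)C(=O)C1(CCC)CCC` is reached from compound 2 by the change (propyl in place of isopropyl on a saturated chain carbon bound to an oxygen on an unsaturated carbon); read one bond further out it is isobutoxy to butoxy. Among the compounds with values here, the only measured step that touches this region is a 1.4-fold higher number from compound 1 to compound 2 (0.15 log units; within the scatter), where a methyl was added on the chain and the number stayed within the scatter. Going from isopropyl to propyl at the same chain keeps the atom count and only unbranches it, so no step beyond the scatter is expected in this assay, with the number for compound 4 estimated near that of compound 2 or slightly lower, as the step of a 1.2-fold lower number from compound 2 to compound 4 (0.07 log units; within the scatter) expresses.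

Compound 4 is therefore estimated at 10.5 uM, within the range 5 uM to 22 uM.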

Compound 4, concentration for half-maximal effect: 9.6 uM
Compound 4: the middle estimate sits 1.1-fold (0.04 log units) above what was measured; measured number inside the range.
By their numbers in this assay, from the lowest: compounds 3, 1, 4 and 2 (each within the scatter of the next, the first and the last beyond it).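

In this assay, unbranching isobutoxy to butoxy gives a 1.3-fold lower number from compound 2 to compound 4 (0.10 log units; within the scatter), so on a saturated chain carbon bound to an oxygen on an unsaturated carbon, the branched and straight chains are not separated. Extending propoxy to butoxy reads a 1.1-fold higher number from compound 1 to compound 4 (0.05 log units; within the scatter), which adds a straight-chain counterpart to the branched extension, a 1.4-fold higher number from compound 1 to compound 2 (0.15 log units; within the scatter); the alkoxy chain thus tolerates the added methyl in either arrangement in this small set. No data bearing on the origin of these steps are at hand.

On these data alone, whether this tolerance holds for a longer chain such as octyloxy, or for a chain ending in an amine or a carboxylic acid, remains open. Compound 3 differs from the others in more than one place, so the effect of its bromine on the phenyl cannot be read apart from its methoxy.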